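A few compounds are considered here, and "the series" means these few. Any claim that something is new, unique, unknown or untested is made for them only; others in the source may bear on it.

In a functional assay on MDA-MB-231 cells (Homo sapiens) for antiproliferative activity, read by MTT assay, with a stated time of 96 h (a lower number here means a stronger inhibitor, a higher number a weaker inhibitor), compound 3, `CC(C)=CCC/C(C)=C/CC/C(C)=C/CC[C@]1(C)CCc2c(C)c(OC(=O)NS(=O)(=O)c3ccccc3)c(C)c(C)c2O1`, gives > 10000 nM, which is a limit and not a number. Compound 1, `CC(C)=CCC/C(C)=C/CC/C(C)=C/CC[C@]1(C)CCc2c(C)c(OC(=O)NS(=O)(=O)c3ccc(Cl)cc3)c(C)c(C)c2O1`, gives > 10000 nM, also a limit. Compound 2, `CC(C)=CCC/C(C)=C/CC/C(C)=C/CC[C@]1(C)CCc2c(C)c(OC(=O)Nc3ccccc3)c(C)c(C)c2O1`, gives > 10000 nM, again a limit. The whole picture is therefore (the limit of > 10000 nM in this assay, at which 3 of the 3 values shown sit).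

Compound 4, `CC(C)=CCC/C(C)=C/CC/C(C)=C/CC[C@]1(C)CCc2c(C)c(OC(=O)NCc3ccccc3)c(C)c(C)c2O1`, carries benzyl in place of phenylsulfonyl on an amide-type nitrogen. The nearest evidence is a step that the two limits leave unreadable from compound 2 to compound 3, which also swaps the group on that nitrogen. a step that the two limits leave unreadable from compound 1 to compound 2 does so too, while a step that the two limits leave unreadable from compound 1 to compound 3 changes only the chloro. None of these offers a size to carry over, so no clear shift is expected in this assay. The expected change is a step that the limit leaves unreadable from compound 3 to compound 4. Compound 4 is estimated at 13000 nM, within an expected range of 5000 nM to 30000 nM.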

Compound 4, half-maximal inhibitory concentration: 7200 nM
Beside the measured number, compound 4's estimate is 1.8-fold (0.26 log units) above it; measured number inside the range.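

Benzyl on the amide-type nitrogen is the first group here to give a measured number in this assay rather than a limit: the limit of > 10000 nM in this assay, at which 3 of the 4 values shown sit. The change gives an at least 1.3-fold lower number from compound 3 to compound 4 (0.14 log units; that floor lies within the scatter), an at least 1.3-fold lower number from compound 2 to compound 4 (0.14 log units; that floor lies within the scatter) and an at least 1.3-fold lower number from compound 1 to compound 4 (0.14 log units; that floor lies within the scatter). From the compounds shown here alone, each of these is only a floor, so the true size of each step stays unknown, and these floors alone do not establish a real change.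

Going by these compounds, it remains open whether a longer chain on that nitrogen, such as phenethyl, or an amine on the benzyl ring would shift the number further.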